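This account rests on a few compounds, and the source may have more. Where it says the series, first, only, none or still open, it means among the compounds named here.

Compound 3, with the structure `N#Cc1ccc(Nc2nccc(NC3CC3)n2)cc1`, is the starting point. In an ADME assay on MT4 cells (Homo sapiens) for cytotoxicity, read by MTT assay (on this read-out lower numbers stand for higher toxicity in this test and higher numbers for lower toxicity in this test), compound 3 gives 1190 nM, the highest of the two plain numbers in the set. Its nearest neighbour is compound 2, built as `Cc1cc(OC2CCCCC2)nc(Nc2ccc(C#N)cc2)n1`, which in this assay gives 320 nM. Compound 1, with the structure `N#Cc1ccc(Nc2nccc(SC3CCCCC3)n2)cc1`, sits at a limit of this assay, > 402000 nM. That limit is the line (the limit of > 402000 nM in this assay, at which 1 of the 3 values shown sits). Going by the values given here, the one measured step in the set runs from compound 1 to compound 3 and is an at least 330-fold lower number from compound 1 to compound 3 (2.52 log units; beyond the scatter), a change on a different part of the core.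

Compound 4, with the structure `Cc1cc(NC2CC2)nc(Nc2ccc(C#N)cc2)n1`, differs from compound 3 by methyl in place of hydrogen on an aromatic carbon. Among the compounds with values here, no measured step tracks this change on its own: compound 2 carries the same methyl but also differs from compound 3 in the group on the other aromatic carbon, so its value alone cannot be read as the effect of the methyl. Within the data shown here, with no measured step bearing directly on it, a small change such as a methyl is expected to give no step beyond the scatter. Compound 4 is therefore expected to give 900 nM in this assay, between 300 nM and 3000 nM, which means an expected step of a 1.3-fold lower number from compound 3 to compound 4 (0.12 log units; within the scatter).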

Compound 4, half-maximal cytotoxic concentration: 88 nM
Compound 4: middle estimate off by 10-fold (1.01 log units), on the high side; the measured number lies below the stated range.
By their numbers in this assay, from the lowest: compound 4; then compound 2; then compound 3. At a limit, above all of these: compound 1.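

In this assay, going by these compounds alone, one methyl in place of hydrogen on an aromatic carbon, next to the ring nitrogen, is enough to give a large step, which the earlier compounds could not show on its own: a 14-fold lower number from compound 3 to compound 4 (1.13 log units; beyond the scatter). With this methyl present in both compounds, the group on the other aromatic carbon still matters, as cyclopropylamino in place of cyclohexyloxy gives a modest step that also lies beyond the scatter: a 3.6-fold lower number from compound 2 to compound 4 (0.56 log units; beyond the scatter). Within the data shown here, nothing at hand bears on why this small change moves the number so far.

The compounds shown leave open whether an ethyl group, a chlorine atom or a methoxy group on the same aromatic carbon would lower the number as far as methyl does, and whether methyl has a step of similar size when cyclohexyloxy stands on the other aromatic carbon. They also leave open how methyl would act alongside the cyclohexylsulfanyl group of compound 1, which gives > 402000 nM, a limit of this assay and not a plain number.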